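Thiophene isomers on a dihydropyrimidine core: A3 binding

The compounds below may be only part of what the source reports. "The series", "measured", "known", "first", "only" and "open" are said of these compounds alone.

Two compounds carry a tert-butyl ester core: compound 1 `CC1=C(C(=O)OC(C)(C)C)C(c2cccs2)NC(=O)N1` and compound 2 `CC1=C(C(=O)OC(C)(C)C)C(c2ccsc2)NC(=O)N1`. In an assay on membranes from HeLa cells for displacement of a labelled ligand from adenosine receptor A3 (Homo sapiens), read by scintillation counting, with a stated time of 180 min, tested at 1 uM (a lower number here means less inhibition, a higher number more inhibition at the concentration tested (going by the name of the read-out)), compound 1 gives 7%, and compound 2 gives 1%. The step between them, (thiophen-3-yl in place of thiophen-2-yl on a saturated ring carbon), gives a number 6 percentage points lower from compound 1 to compound 2 (within the scatter). Compound 3 `COC(=O)C1=C(C)NC(=S)NC1c1cccs1` carries a different core; the difference between the two cores is not broken down here. In this assay compound 3 gives 1%, level with compound 2 at the digits printed. Compound 4 `COC(=O)C1=C(C)NC(=S)NC1c1ccsc1` has not been measured in this assay. It differs from compound 3 by thiophen-3-yl in place of thiophen-2-yl on a saturated ring carbon, the same kind of change as that from compound 1 to compound 2, though here the place is next to the ring atom that bears a methoxycarbonyl group rather than a group of 7 heavy atoms. Given that compound 3 gives 1% and that the earlier step was a number 6 percentage points lower from compound 1 to compound 2 (within the scatter), the step from compound 3 to compound 4 is expected to be no change at the digits printed from compound 3 to compound 4 (within the scatter). Compound 4 is therefore estimated at 1%, with a range of -8% to 10%.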

Compound 4, a percentage reported as inhibition, at one concentration (the size of the read-out at that concentration, not a potency): 3%
Estimate against measurement, compound 4: 2 percentage points below; the range from low to high includes it.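

Thiophen-3-yl in place of thiophen-2-yl on the saturated ring carbon has now been read on two cores in this assay, and on the second core it gives a number 2 percentage points higher from compound 3 to compound 4 (within the scatter). Set beside the earlier step, the second reading does not differ from the first: the same change on two cores in this assay, a number 6 percentage points lower (within the scatter) from compound 1 to compound 2 and a number 2 percentage points higher (within the scatter) from compound 3 to compound 4, 8 percentage points apart, within the scatter of two such steps. This shows that the change stays within the scatter on both cores, but it does not show that the two steps are truly the same, since none of the four compounds shows much inhibition at the single concentration tested and a reading of this kind gives no potency.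

The compounds shown leave open whether the step would hold on a compound with a clearly larger read-out, and how each part of the difference between the two cores contributes on its own. They also leave open what a phenyl or pyridine ring on the same ring carbon, or a carboxylic acid or amide in place of the ester, would give.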